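This account rests on a few compounds, and the source may have more. Where it says the series, first, only, none or still open, it means among the compounds named here.

Values measured so far in an in vitro ADME assay on microsomes from liver (Homo sapiens) for metabolic stability; a higher number here means faster removal of the compound, a lower number slower removal:
- compound 1 `COC(=O)[C@H]1CC[C@@H](n2/c(=N/C(=O)c3ccccc3)[nH]c3ccc(CN4CCCCC4)cc32)CC1` gives 85 mL.min-1.g-1
- compound 2 `CCNC(=O)[C@H]1CC[C@@H](n2/c(=N/C(=O)c3ccccc3)[nH]c3ccc(CN4CCCCC4)cc32)CC1` gives 194 mL.min-1.g-1
- compound 3 `CC(C)NC(=O)[C@H]1CC[C@@H](n2/c(=N/C(=O)c3ccc(F)c(F)c3)[nH]c3ccc(CN4CCC(C(C)(C)O)CC4)cc32)CC1` gives 60 mL.min-1.g-1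

Compound 3 at 60 mL.min-1.g-1 lies within the usual scatter of compound 1 and clearly under compound 2. Compound 4 `CC(C)NC(=O)[C@H]1CC[C@@H](n2/c(=N/C(=O)c3cccnc3)[nH]c3ccc(CN4CCC(C(C)(C)O)CC4)cc32)CC1` differs from compound 3 in one place (pyridin-3-yl in place of 3,4-difluorophenyl on a carbonyl carbon): pyridin-3-yl in place of 3,4-difluorophenyl on a carbonyl carbon. Among the compounds with values here, the only measured step (a 2.3-fold higher number from compound 1 to compound 2 (0.36 log units; beyond the scatter)) was modest and puts ethylamino in place of methoxy on a different carbonyl carbon, so it offers a rough sense of size but no direction for this swap. In this assay a small move to a lower number is expected, as a judgement only (a 1.5-fold lower number from compound 3 to compound 4 (0.18 log units; within the scatter)). For compound 4 the estimate is 40 mL.min-1.g-1 with an expected range from 15 mL.min-1.g-1 to 100 mL.min-1.g-1 around it.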

Compound 4, intrinsic clearance in microsomes: 47 mL.min-1.g-1
Beside the measured number, compound 4's estimate is 1.2-fold (0.07 log units) below it, within the range that was stated.
By their numbers in this assay, from the lowest: compounds 4, 3 and 1 (each within the scatter of the next); then compound 2.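

Within the data shown here, compounds 1 to 3 offered no step that changed only the group on this carbonyl carbon. In this assay, pyridin-3-yl in place of 3,4-difluorophenyl gives a 1.3-fold lower number from compound 3 to compound 4 (0.11 log units; within the scatter), so this exchange of rings, with its loss of both fluorines and gain of a ring nitrogen, cannot be told apart from no change. Nothing available here bears on why the two numbers match.

From the compounds shown here alone, whether pyridin-4-yl or cyclohexyl on this carbonyl carbon would also stay within the scatter of compound 3 remains open. So does whether the same swap would give a similar step with a different amide or amine elsewhere in the molecule.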